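Fluoro on the core of compound 2: expected effect

The compounds below may be only part of what the source reports. "The series", "measured", "known", "first", "only" and "open" are said of these compounds alone.

The series rests on one shared core, carried by compound 1 `CCCS(=O)(=O)N1CC=C(c2ccc3c(c2)CC(C2CCN(c4ccc(C(F)(F)F)cn4)CC2)O3)CC1`, compound 2 `CCCc1cnc(N2CCC(C3Cc4cc(C5=CCN(S(=O)(=O)CCC)CC5)ccc4O3)CC2)nc1` and compound 3 `CCCc1cnc(N2CCC(C3Cc4cc(N5CCN(S(=O)(=O)CCC)CC5)ccc4O3)CC2)nc1`. In a functional assay on HEK293 cells with Glucose-dependent insulinotropic receptor (Homo sapiens) as the target, read by cAMP accumulation, with a stated time of 60 min (a higher number here means a larger maximal response, a lower number a smaller maximal response), compound 2 gives 107%. Compound 1 gives 99% in this assay, and the step of a number 8 percentage points higher from compound 1 to compound 2 (within the scatter) is within the scatter, so the two numbers cannot be told apart. Compound 3 gives 74% in this assay, and the step of a number 33 percentage points lower from compound 2 to compound 3 (beyond the scatter) is beyond the scatter, so compound 2 stands clearly apart from compound 3 and level with compound 1.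

Compound 4 `CCCc1cnc(N2CCC(C3Cc4cc(C5=CCN(S(=O)(=O)CCC)CC5)cc(F)c4O3)CC2)nc1` differs from compound 2 in one place: fluoro in place of hydrogen on an aromatic carbon. Neither measured step bears directly on this change. The step of a number 8 percentage points higher from compound 1 to compound 2 (within the scatter) concerns the group on the amine nitrogen in a ring, and the step of a number 33 percentage points lower from compound 2 to compound 3 (beyond the scatter) concerns the exchange of a whole group on an aromatic carbon; neither touches a single hydrogen of the fused aromatic ring. For the measured compounds named here, the record therefore offers no step of the same kind, and the only guide is that the large change in compound 3 moved the number, while the change in compound 1 did not.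

With so small a change, the account expects no step beyond the scatter, a number 4 percentage points lower from compound 2 to compound 4 (within the scatter), and estimates compound 4 at 103%, between 88% and 118%.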

Compound 4, largest response reached (Emax), in percent of the reference or control that the assay uses: 93%
Compound 4: middle estimate off by 10 percentage points, on the high side; low and high end bracket the measured number.
By their numbers in this assay, from the lowest: compound 3; then compounds 4, 1 and 2 (each within the scatter of the next, the first and the last beyond it).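

Fluoro in place of hydrogen gives a number 14 percentage points lower from compound 2 to compound 4 (beyond the scatter) in this assay and so shows that one heavy atom, added on an aromatic carbon ortho to a fused ring and meta to a large group, can move the maximal response of the shared core beyond the scatter. Among the earlier steps, only the exchange of a whole group on an aromatic carbon had done this, in a number 33 percentage points lower from compound 2 to compound 3 (beyond the scatter) while the replacement of the group on the amine nitrogen had not. Nothing shown here measures what lies behind the lower number for this fluoro compound.

The compounds shown leave open whether a chloro, a methyl or a methoxy group on this same carbon would lower the response as fluoro does, or whether the step belongs to fluoro alone. They also leave open whether fluoro on another aromatic carbon of the ring would have the same effect, and whether this step would recur with the 5-(trifluoromethyl)pyridin-2-yl group in place of the 5-propylpyrimidin-2-yl group.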